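Thioether substituent change on the shared core

The source may report more compounds than this note shows. Statements on the series, on what has been measured and on what is new or still open speak of the compounds shown alone.

Two compounds of the series have numbers. In a functional assay on MGC-803 cells (Homo sapiens) for inhibition, read by MTT assay, with a stated time of 72 h (a lower number here means a stronger inhibitor, a higher number a weaker inhibitor), compound 1 `Cc1cc(Nc2cc(-c3ccccc3)[nH]n2)n2nc(SCc3csc4ccccc34)nc2n1` gives 2280 nM, the lowest of the two numbers. Compound 2 `Cc1cc(Nc2cc(-c3ccc(Cl)cc3)[nH]n2)n2nc(SCc3ccc(Br)cc3)nc2n1` gives 2780 nM in this assay, which is within the scatter of compound 1. Compound 3 `Cc1cc(Nc2cc(-c3ccccc3)[nH]n2)n2nc(SCC3CCCCC3)nc2n1` has not been measured; it differs from compound 1 in one place: cyclohexyl in place of 1-benzothiophen-3-yl on a saturated chain carbon bound to a sulfur. For the measured compounds named here, no measured pair shows this change, so its size cannot be read from the series. A modest step toward a higher number in this assay is expected, though one within the scatter is also possible. The estimate for compound 3 is 3500 nM, between 1500 nM and 9000 nM, which corresponds to the expected step of a 1.5-fold higher number from compound 1 to compound 3 (0.19 log units; within the scatter).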

Compound 3, half-maximal inhibitory concentration: 12600 nM
Beside the measured number, compound 3's estimate is 3.6-fold (0.56 log units) below it, and the stated range ends below it.
By their numbers in this assay, from the lowest: compounds 1 and 2 (each within the scatter of the next); then compound 3.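

On a saturated chain carbon bound to a sulfur, the substituent matters: in this assay, cyclohexyl in place of 1-benzothiophen-3-yl gives a 5.5-fold higher number from compound 1 to compound 3 (0.74 log units; beyond the scatter). For the compounds shown here, this is the first single-place step, and it shows that this position does not tolerate every ring. Going by these compounds alone, nothing measured so far gives a reason for the step.

As far as these compounds go, it remains open whether the aromatic rings, the ring sulfur or the heavy-atom count drives the change. A naphthyl group at this place, with its two aromatic rings of carbon only, would begin to separate these.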